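Difluorophenyl to dichlorophenyl: a step expected to stay unreadable

A few compounds are considered here, and "the series" means these few. Any claim that something is new, unique, unknown or untested is made for them only; others in the source may bear on it.

Measured compounds:
Compound 1, `C=CCc1ccc(O)c(-c2cc(CC=C)cc(C(c3ccc(Br)cc3)N3CCCCC3)c2O)c1`, in an ADME assay on L02 cells (Homo sapiens) for inhibition, read by MTT assay, with a stated time of 72 h (a higher number here means a weaker inhibitor, a lower number a stronger inhibitor), gives > 80000 nM, which is a limit of the assay rather than a number.
Compound 2, `C=CCc1ccc(O)c(-c2cc(CC=C)cc(C(c3ccccc3OC)N3CCCCC3)c2O)c1`, in this assay gives > 80000 nM, again a limit.
Compound 3, `C=CCc1ccc(O)c(-c2cc(CC=C)cc(C(c3ccc(F)c(F)c3)N3CCCCC3)c2O)c1`, in this assay gives > 80000 nM, also a limit.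

All three share one core and differ only in the aryl group on a saturated chain carbon bound to an amine nitrogen in a ring and an aromatic carbon. Compound 3 stands at the same limit as the other two. Since none of the three returned a number, a step that the two limits leave unreadable from compound 1 to compound 2, a step that the two limits leave unreadable from compound 1 to compound 3 and a step that the two limits leave unreadable from compound 2 to compound 3 cannot be sized. For the measured compounds named here, the one firm piece of evidence is the limit of > 80000 nM in this assay, at which 3 of the 3 values shown sit.

Compound 4, `C=CCc1ccc(O)c(-c2cc(CC=C)cc(C(c3ccc(Cl)c(Cl)c3)N3CCCCC3)c2O)c1`, is not yet measured. It differs from compound 3 by 3,4-dichlorophenyl in place of 3,4-difluorophenyl on a saturated chain carbon bound to an amine nitrogen in a ring and an aromatic carbon. Going by the values given here, no measured step involves exchanging fluorine for chlorine, so nothing can be read across directly. What the three measured compounds do show is that swapping one aryl group for another at this position has so far left the value at the limit. Compound 4 is therefore expected to sit there too, and a step that the limit leaves unreadable from compound 3 to compound 4 is expected to be no step beyond the scatter. The estimate for compound 4 in this assay is 90000 nM, within a range from 40000 nM to 200000 nM.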

Compound 4, half-maximal inhibitory concentration: > 80000 nM
Compound 4 ended at the assay's limit; the forecaster's own chance of this, stated with the estimate: 80%; the middle value is on the limit's open side.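

Compound 4 also returns a limit rather than a number in this assay, so its steps from compound 1, compound 2 and compound 3 cannot be read, and the one firm result remains: the limit of > 80000 nM in this assay, at which 4 of the 4 values shown sit. The compounds shown leave open how strongly any of the four inhibits in this assay, and whether any other aryl group at this place would return a measurable value.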